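A Dimethylaminophenyl Swap on a Shared Core

The compounds below may be only part of what the source reports. "The series", "measured", "known", "first", "only" and "open" are said of these compounds alone.

The measured compounds, all read in an assay for binding affinity to dual specificity mitogen-activated protein kinase kinase 4 (Homo sapiens), read by KINOMEscan, tested at 100 nM; a lower number here means a stronger effect, a higher number a weaker effect of the compound at the concentration tested:

Compound 1, `CCCS(=O)(=O)Nc1ccc(F)c(C(=O)c2n[nH]c3ncc(-c4ccccc4F)cc23)c1F`, gives 2%.
Compound 2, `CCCS(=O)(=O)Nc1ccc(F)c(C(=O)c2n[nH]c3ncc(-c4ccccc4OC)cc23)c1F`, gives 1.9%.
Compound 3, `CCCS(=O)(=O)Nc1ccc(F)c(C(=O)c2n[nH]c3ncc(-c4ccccc4N)cc23)c1F`, gives 23%.

Compound 2 holds the lowest of the three numbers in this assay. Its nearest neighbour is compound 1, with the difference a number 0.1 percentage points lower from compound 1 to compound 2 (within the scatter) lying within the scatter; its furthest is compound 3, reached by the step of a number 21.1 percentage points higher from compound 2 to compound 3 (beyond the scatter), which goes beyond the scatter. The parallel step a number 21 percentage points higher from compound 1 to compound 3 (beyond the scatter) shows the same modest rise when amino replaces fluoro.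

Compound 4, `CCCS(=O)(=O)Nc1ccc(F)c(C(=O)c2n[nH]c3ncc(-c4cccc(N(C)C)c4)cc23)c1F`, has not yet been measured. It differs from compound 2 in one place: 3-(dimethylamino)phenyl in place of 2-methoxyphenyl on an aromatic carbon. Among the compounds with values here, no measured step covers this exact exchange. Within the data shown here, the only steps that touch an amino-type group on that ring, from compound 1 and compound 2 to compound 3, each raised the read-out beyond the scatter, while the exchange of fluoro for methoxy stayed within the scatter. A nitrogen-bearing substituent on the ring therefore points toward a higher number, but here the substituent sits on a different ring carbon and carries two methyl groups, so the comparison is loose.

Among the measured compounds shown here, compound 4 is expected to show a step of a number 8.1 percentage points higher from compound 2 to compound 4 (within the scatter) in this assay, a rise smaller than the one to compound 3. The estimate for compound 4 is 10%, with a plausible range from 1% to 40%.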

Compound 4, a percentage reported as activity, at one concentration (the size of the read-out at that concentration, not a potency): 26%
For compound 4 the middle estimate is 16 percentage points below the measured one, and the stated range covers the measured number.
By their numbers in this assay, from the lowest: compounds 2 and 1 (each within the scatter of the next); then compounds 3 and 4 (each within the scatter of the next).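

In this assay, the step of a number 24.1 percentage points higher from compound 2 to compound 4 (beyond the scatter) and the step of a number 24 percentage points higher from compound 1 to compound 4 (beyond the scatter) show that the rise seen with 2-aminophenyl on this aromatic carbon of the shared core is not confined to that group, since 3-(dimethylamino)phenyl, a second nitrogen-bearing aryl group, also moves the number beyond the scatter from both low-reading compounds. The step of a number 3 percentage points higher from compound 3 to compound 4 (within the scatter) leaves the two nitrogen-bearing groups indistinguishable in this assay, even though they differ in where the nitrogen sits on the phenyl ring and in the two methyl groups it carries, so among these four compounds the aryl groups fall into a low pair and a higher pair. Nothing shown explains why the nitrogen-bearing groups read higher than 2-fluorophenyl and 2-methoxyphenyl.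

The exchange leading to compound 4 alters the substituent and its place on the phenyl ring together, which leaves the contribution of each unresolved. As far as these compounds go, it also remains open whether a morpholine or a carboxylic acid on that phenyl ring would fall with the low pair or the higher pair.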